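Chlorophenyl dienone series: relocating the chlorine on the aryl ring

A few compounds are considered here, and "the series" means these few. Any claim that something is new, unique, unknown or untested is made for them only; others in the source may bear on it.

Compound 1 `CC1=C(/C=C/C(=O)/C=C/c2ccc(Cl)cc2)C(C)(C)CCC1` gives 10200 nM in a functional assay on MCF7 cells (Homo sapiens) for cytotoxicity, read by sulforhodamine B assay, with a stated time of 48 h; a higher number here means a weaker inhibitor, a lower number a stronger inhibitor; among the three compounds measured this is the second highest number, with compound 3 `CC1=C(/C=C/C(=O)/C=C/c2ccc(C#N)cc2)C(C)(C)CCC1` the nearest at 13200 nM and compound 2 `CC1=C(/C=C/C(=O)/C=C/c2ccc(F)cc2)C(C)(C)CCC1` the furthest at 6200 nM. For the measured compounds named here, the steps between them stay small: a 1.6-fold lower number from compound 1 to compound 2 (0.22 log units; within the scatter) and a 1.3-fold higher number from compound 1 to compound 3 (0.11 log units; within the scatter) both fall within the scatter, while a 2.1-fold higher number from compound 2 to compound 3 (0.33 log units; beyond the scatter) is the only step beyond it, and a modest one.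

Compound 4 `CC1=C(/C=C/C(=O)/C=C/c2ccccc2Cl)C(C)(C)CCC1` differs from compound 1 by 2-chlorophenyl in place of 4-chlorophenyl on a double-bonded chain carbon bound to a double-bonded chain carbon. Going by the values given here, none of the measured steps bears directly on this change: each of the three exchanges the group on an aromatic carbon for another group, and none relocates the same group on the ring. The numbers shown therefore give no direction for the new step, and in this assay the expected step of a 1.0-fold lower number from compound 1 to compound 4 (0.01 log units; within the scatter) is none beyond the scatter. Compound 4 is estimated at 10000 nM in this assay, with a range from 4000 nM to 25000 nM.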

Compound 4, half-maximal inhibitory concentration: 54600 nM
Compound 4: middle estimate off by 5.5-fold (0.74 log units), on the low side; the whole stated range lies below it.
By their numbers in this assay, from the lowest: compounds 2, 1 and 3 (each within the scatter of the next, the first and the last beyond it); then compound 4.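

In this assay, 2-chlorophenyl in place of 4-chlorophenyl gives a step beyond the scatter (a 5.4-fold higher number from compound 1 to compound 4 (0.73 log units; beyond the scatter)), although the atoms are the same, so the arrangement at this place on the chain alters the number where the earlier exchanges of one group for another moved it little or not beyond the scatter. The change is larger still when measured against 4-fluorophenyl (an 8.8-fold higher number from compound 2 to compound 4 (0.94 log units; beyond the scatter)), the largest step listed in the series. No measurement shown here accounts for either step.

Going by these compounds, whether fluoro or cyano, relocated in the same way as the chlorine, would give a step of similar size remains open. Also open, on these data alone, is how an amine or a carboxylic acid on the aromatic ring would read in this assay, in either arrangement.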